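Swapping 2-nitrophenyl for 4-nitrophenyl in compound 3

The source may report more compounds than this note shows. Statements on the series, on what has been measured and on what is new or still open speak of the compounds shown alone.

In a functional assay on MCF7 cells (Homo sapiens) for cytotoxicity, read by sulforhodamine B assay (a lower number here means that less compound is tolerated, a higher number that more compound is tolerated), compound 1 (`CC1=CC[C@@H]([C@@](C)(O)CCCC(C)(C)NC(=S)N/N=C\c2ccccc2)CC1`) gives 60400 nM. Compound 2 (`CC1=CC[C@@H]([C@@](C)(O)CCCC(C)(C)NC(=S)N/N=C\c2ccccc2[N+](=O)[O-])CC1`) reads > 100000 nM, which is a limit of the assay and not a number. Compound 3 (`CC1=CC[C@@H]([C@@](C)(O)CCCC(C)(C)NC(=S)N/N=C\c2ccc([N+](=O)[O-])cc2)CC1`) carries 4-nitrophenyl in place of 2-nitrophenyl on a carbon with a double bond to nitrogen. For the measured compounds named here, the one measured step bearing on this is an at least 1.6-fold higher number from compound 1 to compound 2 (0.21 log units; that floor lies within the scatter), with nitro in place of hydrogen on an aromatic carbon. Going by the values given here, that step is only a floor, and no measurement yet covers 4-nitrophenyl. The expected change is an at least 1.2-fold lower number from compound 2 to compound 3 (0.09 log units; that floor lies within the scatter), so nothing beyond the scatter is anticipated in this assay. For compound 3 the estimated value is 80000 nM, with an expected range from 35000 nM to 160000 nM.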

Compound 3, concentration lethal to 50% of the cells: > 100000 nM
Compound 3: only a limit was reported; the forecaster's own chance of this, stated with the estimate: 40%; middle value at least 1.2-fold (0.09 log units) away from the limit.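

Compound 3, with 4-nitrophenyl, reads > 100000 nM in this assay, which is a limit of the assay and not a number. Nitro in place of hydrogen on an aromatic carbon, now in this second arrangement, gives an at least 1.6-fold higher number from compound 1 to compound 3 (0.21 log units; that floor lies within the scatter). The step between compound 2 and compound 3 cannot be read because both values are limits: the limit of > 100000 nM in this assay, at which 2 of the 3 values shown sit.

On these data alone, how far compound 2 and compound 3 truly lie from compound 1 therefore stays open. Also open, as far as these compounds go, is how an amine or a carboxylic acid in place of nitro would read in this assay.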